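Compound 3: an estimate starting from a limit

The source may hold more compounds than are shown below. What is called first, only, known or untested is meant among the compounds shown, and "the series" means these compounds.

Compound 1 `Oc1ccc([C@@H]2C/C(=N\Nc3ccc(Br)cn3)c3c(O)cc(O)cc3O2)cc1` gives >= 11300 nM (a limit)
Compound 2 `Cn1cccc1/C=N/N=C1\C[C@@H](c2ccc(O)cc2)Oc2cc(O)cc(O)c21` gives >= 11300 nM (a limit)

In a functional assay on L5178Y cells (Mus musculus) for inhibition, read by MTT assay, with a stated time of 24 h (a lower number here means a stronger inhibitor, a higher number a weaker inhibitor), compound 2 stands only at a limit, >= 11300 nM as reported, and not at a true number. Compound 3 `O=C(N/N=C1\C[C@@H](c2ccc(O)cc2)Oc2cc(O)cc(O)c21)c1cccs1` carries a ((thiophen-2-yl)carbonyl)amino group on the double-bonded nitrogen instead (a group of 8 heavy atoms (5 carbon, 1 nitrogen, 1 oxygen, 1 sulfur; one five-membered aromatic ring with 1 hetero atom) in place of a group of 8 heavy atoms (6 carbon, 2 nitrogen; one five-membered aromatic ring with 1 hetero atom), on a double-bonded nitrogen). Within the data shown here, the one measured step (a step that the two limits leave unreadable from compound 1 to compound 2) changed the group at this same place, yet it has no readable size. Among the measured compounds shown here, both measured compounds sit at the same limit (the limit of >= 11300 nM in this assay, at which 2 of the 2 values shown sit), so no measured step offers a size or a direction to carry over. The expectation is therefore no change beyond the usual scatter, and compound 3 may well report only a limit too. The estimated step is a step that the limit leaves unreadable from compound 2 to compound 3 in this assay on this reasoning. Compound 3 is expected at 14000 nM with an estimated range from 6000 nM to 30000 nM if a number is obtained.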

Compound 3, half-maximal inhibitory concentration: >= 11300 nM
Compound 3: only a limit was reported; the forecaster's own chance of this, stated with the estimate: 65%; the middle value lies beyond the limit too.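

Compound 3, like compound 1 and compound 2, gives only a limit in this assay, so no step among these three compounds can be read. The compounds shown leave open how strongly each one truly inhibits and whether the group on the double-bonded nitrogen matters at all: the limit of >= 11300 nM in this assay, at which 3 of the 3 values shown sit.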